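Trifluoromethyl for Methyl on a Weakly Cytotoxic Series

The source may report more compounds than this note shows. Statements on the series, on what has been measured and on what is new or still open speak of the compounds shown alone.

Of the compounds shown here, three built on one shared core have been measured in a functional assay on HeLa cells (Homo sapiens) for cytotoxicity, read by cell counting, with a stated time of 4 days; on this read-out higher numbers stand for weaker inhibition and lower numbers for stronger inhibition. Compound 1 `Nc1ccc(/C=C2\SC(=O)N(Cc3ccc(C(F)(F)F)cc3)C2=O)cc1` gives 96000 nM. Compound 2 `Nc1cccc(/C=C2\SC(=O)N(Cc3ccc(F)cc3)C2=O)c1` gives 86000 nM in this assay. Compound 3 `Cc1ccc(CN2C(=O)S/C(=C\c3cccc(N)c3)C2=O)cc1` gives 98000 nM in this assay. Compound 3 holds the highest of the three numbers, yet its nearest neighbour, compound 1, sits only a hair below it and its furthest, compound 2, is still within the scatter, so the three values cannot be told apart. For the measured compounds named here, the only one-place step among them, a 1.1-fold higher number from compound 2 to compound 3 (0.06 log units; within the scatter), shows that exchanging a substituent on the benzyl ring left the read-out unmoved.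

Compound 4 `Nc1cccc(/C=C2\SC(=O)N(Cc3ccc(C(F)(F)F)cc3)C2=O)c1` differs from compound 3 by trifluoromethyl in place of methyl on an aromatic carbon. That step bears directly on the measured one, which was within the scatter, and compound 1, carrying the same trifluoromethyl group, gives 96000 nM, a number indistinguishable from that of compound 3. On this basis the step of a 1.0-fold lower number from compound 3 to compound 4 (0.01 log units; within the scatter) is expected to stay within the scatter. Compound 4 is therefore estimated at 95000 nM, with a range from 45000 nM to 200000 nM.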

Compound 4, half-maximal inhibitory concentration: > 250000 nM
Compound 4 gave a limit, no number; the forecaster's own chance of this, stated with the estimate: 25%; at least 2.6-fold (0.42 log units) between middle value and limit.
By their numbers in this assay, from the lowest: compounds 2, 1 and 3 (each within the scatter of the next). At a limit, above all of these: compound 4.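

For compound 4, this assay returned a limit and not a number: the limit of > 250000 nM in this assay, at which 1 of the 4 values shown sits. For the compounds shown here, at this place, on an aromatic carbon para to a large group, trifluoromethyl in place of methyl is the first change to go beyond the scatter, with an at least 2.5-fold higher number from compound 3 to compound 4 (0.40 log units; beyond the scatter), and trifluoromethyl in place of fluoro gives an at least 2.9-fold higher number from compound 2 to compound 4 (0.46 log units; beyond the scatter), whereas methyl in place of fluoro stayed within it, with a 1.1-fold higher number from compound 2 to compound 3 (0.06 log units; within the scatter). Trifluoromethyl alone does not set the result, as compound 1 carries it too, and 3-aminophenyl in place of 4-aminophenyl gives an at least 2.6-fold higher number from compound 1 to compound 4 (0.41 log units; beyond the scatter), so the place of the amine on the aminophenyl group counts as well.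

On these data alone, all three new steps rest on a limit, so their full size stays open, and the series shows only that the read-out can move in the direction of weaker inhibition. As far as these compounds go, whether a chlorine atom, a methoxy group or a nitrile at the place of the trifluoromethyl would move the read-out in the same way, and whether a hydroxyl group in place of the amine would keep the difference between 3-aminophenyl and 4-aminophenyl, remains open.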